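The source may report more compounds than this note shows. Statements on the series, on what has been measured and on what is new or still open speak of the compounds shown alone.

Compound 1 `Oc1ccccc1-c1cc(-c2ccsc2)cc(-c2ccccc2O)n1`: in a functional assay on DU-145 cells (Homo sapiens) for cytotoxicity, read by CCK-8 assay (on this read-out higher numbers stand for weaker inhibition and lower numbers for stronger inhibition), compound 1 gives > 50000 nM, a limit of the assay rather than a number.
Compound 2 `Oc1ccccc1-c1cc(-c2ccco2)cc(-c2ccccc2O)n1`: in this assay compound 2 gives > 50000 nM, again only a limit.
Compound 3 `Oc1ccccc1-c1cc(-c2ccoc2)cc(-c2ccccc2O)n1`: in this assay compound 3 gives > 50000 nM, also a limit.

Compound 3 therefore stands where every measured compound stands, at the limit (the limit of > 50000 nM in this assay, at which 3 of the 3 values shown sit). The three steps among the measured compounds, a step that the two limits leave unreadable from compound 1 to compound 2, a step that the two limits leave unreadable from compound 1 to compound 3 and a step that the two limits leave unreadable from compound 2 to compound 3, are unreadable in size, so none of them shows how much swapping one small aromatic ring for another matters here. Compound 4 `Oc1ccccc1-c1cc(-c2ccccn2)cc(-c2ccccc2O)n1` differs from compound 3 by pyridin-2-yl in place of furan-3-yl on an aromatic carbon. With all three measured values sitting at the limit (the limit of > 50000 nM in this assay, at which 3 of the 3 values shown sit), compound 4 is expected to stay at or near that limit as well, and its step that the limit leaves unreadable from compound 3 to compound 4 is estimated not to exceed the scatter. The estimate for compound 4 is 80000 nM, expected to fall between 20000 nM and 300000 nM.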

Compound 4, half-maximal inhibitory concentration: > 50000 nM
Compound 4 gave a limit, no number; the forecaster's own chance of this, stated with the estimate: 85%; the middle value is on the limit's open side.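

Compound 4 joins compound 1, compound 2 and compound 3 as a limit, so no new step can be read: the limit of > 50000 nM in this assay, at which 4 of the 4 values shown sit. Still open, on these data alone, is whether any ring at this place on the shared core gives a readable number in this assay rather than a limit.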